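The source may report more compounds than this note shows. Statements on the series, on what has been measured and on what is new or still open speak of the compounds shown alone.

Working notes on the series.

The shared core carries a bromine and a benzylamino group in compound 1 `O=C(NCc1ccc(F)cc1)c1nc(Br)c2cccnc2c1NCc1ccccc1`. In a functional assay on HCT-116 cells (Homo sapiens) for cytotoxicity, read by MTT assay, with a stated time of 72 h (on this read-out higher numbers stand for weaker inhibition and lower numbers for stronger inhibition), compound 1 gives > 20000 nM, and this is a limit of the assay rather than a number. Within this assay compound 1 is the only entry with a measured result; its standing rests on (the limit of > 20000 nM in this assay, at which 1 of the 3 values shown sits). Compound 2 `C[C@@H](CO)Nc1nc(C(=O)NCc2ccc(F)cc2)c(O)c2ncccc12` and compound 3 `C[C@H](CO)Nc1nc(C(=O)NCc2ccc(F)cc2)c(O)c2ncccc12` replace the bromine with a hydroxyl and the benzylamino group with a hydroxypropylamino group; in this assay compound 2 gives "not determined" (no result reported) and compound 3 gives "not determined" (no result reported). The two are related by the fact that compounds 2 and 3 differ only in the configuration as drawn, so no comparison between them can be drawn here.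

The step under consideration is from compound 1 to compound 4 `C[C@H](Nc1c(C(=O)NCc2ccc(F)cc2)nc(Br)c2cccnc12)c1ccccc1`. The change is methyl in place of hydrogen on a saturated chain carbon bound to an aromatic carbon and a nitrogen on an aromatic ring. Within the data shown here, no measured step between any two compounds in this assay is available, so the size of this step has no precedent.

With compound 1 sitting at the limit, no move beyond the scatter is expected from compound 4 in this assay, and the estimated step is a step that the limit leaves unreadable from compound 1 to compound 4. Compound 4 is therefore expected at 30000 nM in this assay, within a range of 8000 nM to 100000 nM, most likely again reported only as a limit.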

Compound 4, half-maximal inhibitory concentration: > 20000 nM
Compound 4: a limit, no number; the forecaster's own chance of this, stated with the estimate: 75%; the middle value does not contradict the limit.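

No new step can be read: in this assay, compound 1 and compound 4 are each recorded only as a limit of the assay, and the step between them cannot be read. The compounds shown leave open whether the change from benzylamino to (1-phenylethyl)amino shifts the result in this assay at all.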